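The source may hold more compounds than are shown below. What is called first, only, known or untested is meant among the compounds shown, and "the series" means these compounds.

Series notes, hydroxyphenyl-substituted pyridines as inhibitors in an assay on isolated protein for inhibition of DNA topoisomerase 1 (Homo sapiens), with a stated time of 30 min, tested at 20 uM; on this read-out higher numbers stand for a stronger effect at the one concentration tested and lower numbers for a weaker effect.

Compound 1 `Oc1cccc(-c2cc(-c3ccoc3)cc(-c3cccc(O)c3)n2)c1` gives 2% in this assay. Compound 2 `Oc1ccc(-c2cc(-c3ccoc3)cc(-c3cccc(O)c3)n2)cc1` gives 1.3%, and compound 3 `Oc1cccc(-c2cc(-c3cccnc3)cc(-c3cccc(O)c3)n2)c1` gives 1.9%. All three numbers sit close to the floor of the read-out, and none of the steps between them leaves the scatter.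

From compound 1 to compound 2 the change is 4-hydroxyphenyl in place of 3-hydroxyphenyl on an aromatic carbon, and the step is a number 0.7 percentage points lower from compound 1 to compound 2 (within the scatter). From compound 1 to compound 3 the cores differ by pyridin-3-yl in place of furan-3-yl on an aromatic carbon, with a step of a number 0.1 percentage points lower from compound 1 to compound 3 (within the scatter). Compound 2 and compound 3 have no counted difference between them; their values show only that both lie near the floor.

Compound 4 `Oc1ccc(-c2cc(-c3cccnc3)cc(-c3cccc(O)c3)n2)cc1` has not yet been run in this assay. It differs from compound 3 by 4-hydroxyphenyl in place of 3-hydroxyphenyl on an aromatic carbon. Among the measured compounds shown here, this is the same kind of change as the one from compound 1 to compound 2, not the same: in compound 1 the place is meta to a furan-3-yl group, in compound 3 it is meta to a pyridin-3-yl group.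

The step from compound 3 to compound 4 is expected to be a number 0.6 percentage points lower from compound 3 to compound 4 (within the scatter), about the size of the earlier one, resting on compound 1 to compound 2 giving a number 0.7 percentage points lower from compound 1 to compound 2 (within the scatter) and on compound 3 sitting at 1.9%. Compound 4 is therefore estimated at 1.3%, with a range from -5% to 8%.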

Compound 4, a percentage reported as inhibition, at one concentration (the size of the read-out at that concentration, not a potency): 2.8%
Compound 4: the middle estimate sits 1.5 percentage points below what was measured, and the stated range covers the measured number.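

In this assay, 4-hydroxyphenyl in place of 3-hydroxyphenyl gives a number 0.9 percentage points higher from compound 3 to compound 4 (within the scatter), and pyridin-3-yl in place of furan-3-yl gives a number 1.5 percentage points higher from compound 2 to compound 4 (within the scatter); with all four numbers close to the floor of the read-out, neither step shows an effect of the change itself. The hydroxyphenyl change does not differ measurably between the two cores that carry it, although this agreement among near-floor numbers does not show that an effect carries over: the same change on two cores in this assay, a number 0.7 percentage points lower (within the scatter) from compound 1 to compound 2 and a number 0.9 percentage points higher (within the scatter) from compound 3 to compound 4, 1.6 percentage points apart, within the scatter of two such steps. The pyridin-3-yl change reads the same way, and again this shows only the absence of a detectable difference, not a shared effect: the same change on two cores in this assay, a number 0.1 percentage points lower (within the scatter) from compound 1 to compound 3 and a number 1.5 percentage points higher (within the scatter) from compound 2 to compound 4, 1.6 percentage points apart, within the scatter of two such steps.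

All four compounds carry two hydroxyphenyl groups and either a furan-3-yl or a pyridin-3-yl group, which leaves open how the read-out responds to an amine or a carboxylic acid in place of a hydroxyl group, or to a longer chain in place of the furan-3-yl or pyridin-3-yl group. Also open, from the compounds shown here alone, is whether either change would carry from one core to another on a compound whose number stands well clear of the floor.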